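Ring methyl added to compound 2: expected growth inhibition

The source may hold more compounds than are shown below. What is called first, only, known or untested is meant among the compounds shown, and "the series" means these compounds.

Compound 1 `N/C(=N\NC(=S)N1CCCCCC1)c1ccccn1` and compound 2 `N/C(=N\NC(=S)N1CCOCC1)c1ccccn1` share one core. In a functional assay on A-431 cells (Homo sapiens) for cytotoxicity, read by MTT assay, with a stated time of 72 h, tested at 100 uM (on this read-out lower numbers stand for less inhibition of growth and higher numbers for more inhibition of growth at the one concentration tested), compound 1 gives 77.5% and compound 2 gives 84.6%; the two numbers lie within the scatter of each other, so neither stands apart from the other. Compound 3 `Cc1ccnc(/C(N)=N/NC(=S)N2CCOCC2)c1` is not yet measured. It differs from compound 2 by methyl in place of hydrogen on an aromatic carbon — methyl in place of hydrogen on an aromatic carbon. Within the data shown here, no measured pair shows the weight of such a change, and no step beyond the scatter is expected in either direction. For compound 3 the expected value is 80%, between 60% and 95%, an expected step of a number 4.6 percentage points lower from compound 2 to compound 3 (within the scatter).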

Compound 3, percent growth inhibition at one concentration: 82.8%
Beside the measured number, compound 3's estimate is 2.8 percentage points below it; measured number inside the range.
By their numbers in this assay, from the lowest: compounds 1, 3 and 2 (each within the scatter of the next).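

In this assay, among these compounds, methyl in place of hydrogen on an aromatic carbon, opposite the ring nitrogen, gives a number 1.8 percentage points lower from compound 2 to compound 3 (within the scatter) and so supplies the first measured step for this change. At this position, a single added carbon leaves growth inhibition at one concentration inseparable from that of the unsubstituted parent. No available evidence bears on the reason for this result.

On these data alone, whether an amine, a carboxylic acid or a longer chain at this position would produce a step beyond the scatter remains open. Also open, as far as these compounds go, is whether the same methyl would behave alike on compound 1.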